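The source may report more compounds than this note shows. Statements on the series, on what has been measured and on what is new or still open speak of the compounds shown alone.

Measured compounds:
compound 1, `O=C(Nc1cccc(-n2cc(-c3ccncc3)c(-c3ccc(Cl)c(O)c3)n2)c1)Nc1cccc(C(F)(F)F)c1`: in a functional assay on HCT-15 cells (Homo sapiens) for inhibition, read by sulforhodamine B assay, with a stated time of 48 h (a higher number here means a weaker inhibitor of growth, a lower number a stronger inhibitor of growth), compound 1 gives 1510 nM
compound 2, `O=C(Nc1cccc(-n2cc(-c3ccncc3)c(-c3ccc(Cl)c(O)c3)n2)c1)Nc1ccc(Cl)c(Cl)c1`: in this assay compound 2 gives 1230 nM
compound 3, `COc1cc(-c2nn(-c3cccc(NC(=O)Nc4ccc(Cl)c(C(F)(F)F)c4)c3)cc2-c2ccncc2)ccc1Cl`: in this assay compound 3 gives 1230 nM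

Compound 3 stands level with compound 2 at the digits shown, the two together the lowest of the three numbers; compound 1 differs from them only within the scatter. For the measured compounds named here, the one measured step, a 1.2-fold lower number from compound 1 to compound 2 (0.09 log units; within the scatter), concerns the aryl on the urea nitrogen and lies within the scatter.

Compound 4, `O=C(Nc1cccc(-n2cc(-c3ccncc3)c(-c3ccc(Cl)c(O)c3)n2)c1)Nc1ccc(Cl)c(C(F)(F)F)c1`, is reached from compound 3 by hydrogen in place of methyl on an oxygen on an aromatic ring. Going by the values given here, no measured pair turns on this change alone: compounds 1 and 2 carry the hydroxy group and compound 3 the methoxy group, but those pairs also differ in the aryl on the urea nitrogen, and all three numbers sit within the scatter of one another. The step of a 1.1-fold higher number from compound 3 to compound 4 (0.02 log units; within the scatter) in this assay is therefore expected to be none beyond the scatter. Compound 4 is estimated at 1300 nM, with a range of 650 nM to 2600 nM.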

Compound 4, concentration for 50% growth inhibition: 867 nM
For compound 4 the middle estimate is 1.5-fold (0.18 log units) above the measured one, and the stated range covers the measured number.
By their numbers in this assay, from the lowest: compounds 4, 2, 3 and 1 (each within the scatter of the next).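

In this assay, the change from 4-chloro-3-methoxyphenyl to 4-chloro-3-hydroxyphenyl now has a matched pair, with a 1.4-fold lower number from compound 3 to compound 4 (0.15 log units; within the scatter), so hydrogen and methyl on this oxygen cannot be told apart at this level of measurement. The aryl on the urea nitrogen also gains two steps among the hydroxy compounds, a 1.4-fold lower number from compound 2 to compound 4 (0.15 log units; within the scatter) for trifluoromethyl in place of chloro and a 1.7-fold lower number from compound 1 to compound 4 (0.24 log units; within the scatter) for chloro in place of hydrogen, and neither step separates the compounds. No evidence on the cause of any of these steps is available.

On these data alone, whether a longer chain on this oxygen, such as propyl, or an amine in place of the hydroxy group would give a step beyond the scatter stays open. With all four compounds within the scatter of the next, the series gives no ranking.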